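The source may hold more compounds than are shown below. What is called first, only, known or untested is meant among the compounds shown, and "the series" means these compounds.

Series notes. In an assay on CHO cells for binding affinity to Gonadotropin-releasing hormone receptor (Homo sapiens), read by radioligand binding (a higher number here means a weaker inhibitor, a lower number a stronger inhibitor), compound 1 `Cc1cc(-c2c(O)nc3cc(Cl)c(C(=O)Nc4cnsn4)cc3c2OCCC2CC3CCN2CC3)cc(C)c1C` gives 0.6 nM. Going by the values given here, compound 2 `Cc1cc(-c2c(O)nc3cc(Cl)c(C(=O)Nc4cnsn4)cc3c2OCC[C@H]2CCO2)cc(C)c1C` gives 0.9 nM in this assay; of the two numbers measured so far this is the higher, but the step of a 1.5-fold higher number from compound 1 to compound 2 (0.18 log units; within the scatter) is within the scatter, so no order between the two can be read. Compound 3 `Cc1cc(-c2c(O)nc3cc(Cl)c(C(=O)Nc4cnsn4)cc3c2OCCC2CCCC2)cc(C)c1C` is not yet measured; it carries cyclopentyl in place of oxetan-2-yl on a saturated chain carbon, two bonds along the chain from an oxygen on an aromatic ring. Among the compounds with values here, the only measured step that touches this position is a 1.5-fold higher number from compound 1 to compound 2 (0.18 log units; within the scatter), where a different substituent on the same saturated chain carbon was replaced by the oxetan-2-yl group without any change beyond the scatter. A further swap at this position, this time to cyclopentyl, is therefore expected to give no more than a small step, no change at the digits printed from compound 2 to compound 3 (within the scatter), with no preferred direction. For compound 3 the expected value in this assay is 0.9 nM, with a range from 0.3 nM to 3 nM.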

Compound 3, half-maximal inhibitory concentration: 243 nM
Compound 3: middle estimate off by 270-fold (2.43 log units), on the low side, outside the stated range (above it).
By their numbers in this assay, from the lowest: compounds 1 and 2 (each within the scatter of the next); then compound 3.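

In this assay, replacing oxetan-2-yl with cyclopentyl gives a 270-fold higher number from compound 2 to compound 3 (2.43 log units; beyond the scatter), and replacing the group of compound 1 with cyclopentyl gives a 410-fold higher number from compound 1 to compound 3 (2.61 log units; beyond the scatter), so this position is not indifferent to the group it carries. Among these three compounds, heavy-atom count does not order the numbers: the cyclopentyl group falls between the other two groups in size, yet only compound 3 separates from the rest, and it alone carries a group of carbon only. No available evidence bears on the origin of this large step.

On these data alone, it remains open whether the separation goes with the absence of a ring hetero atom or is particular to cyclopentyl. Cyclobutyl, the carbon-only counterpart of oxetan-2-yl, and a pyrrolidin-2-yl ring, an amine of similar size to cyclopentyl, would bear on that question.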